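A few compounds are considered here, and "the series" means these few. Any claim that something is new, unique, unknown or untested is made for them only; others in the source may bear on it.

Working notes on the series in a physicochemical assay for lipophilicity, read by HPLC, measured as octanol-water partition; on this read-out lower numbers stand for lower lipophilicity and higher numbers for higher lipophilicity. Compound 1 `COc1ccc(N(CC(=O)NCCC[Te]c2ccccc2)C(=O)c2ccccc2)cc1` gives 1.72. Compound 2 `COc1ccc(N(CC(=O)NCCCSc2ccccc2)C(=O)CNC(=O)OC(C)(C)C)cc1` gives 3.12. Compound 3 `COc1ccc(N(CC(=O)NCCCSc2ccccc2)C(=O)C#Cc2ccccc2)cc1` gives 3.4, the highest of the three numbers, although its gap to compound 2 is within the scatter and only its gap to compound 1 is beyond it. Within the data shown here, the single measured step at the same carbonyl carbon, a number 0.28 log units higher from compound 2 to compound 3 (within the scatter), stayed within the scatter. Compound 4 `COc1ccc(N(CC(=O)NCCCSc2ccccc2)C(=O)c2ccccc2)cc1` differs from compound 3 as follows: phenyl in place of 2-phenylethynyl on a carbonyl carbon. Among the measured compounds shown here, no measured step matches this change; compound 1 shares the benzoyl group but stands far lower, and no step between it and compound 4 is known. For compound 4 a small downward step is expected, a number 0.40 log units lower from compound 3 to compound 4 (beyond the scatter), possibly within the scatter. The estimate for compound 4 is 3, with a range from 2.5 to 3.5.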

Compound 4, partition coefficient: 3.1
Compound 4: middle estimate off by 0.10 log units, on the low side, and the stated range covers the measured number.
By their numbers in this assay, from the lowest: compound 1; then compounds 4, 2 and 3 (each within the scatter of the next).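

In this assay, a number 0.30 log units lower from compound 3 to compound 4 (within the scatter) and a number 0.02 log units lower from compound 2 to compound 4 (within the scatter) put phenyl, 2-phenylethynyl and ((tert-butoxycarbonyl)amino)methyl on this carbonyl carbon all within the scatter of one another. Compound 4 also gives compound 1 its first single-place comparison: with the sulfur-bearing group in place of the tellurium-bearing group on the saturated chain carbon, a number 1.38 log units higher from compound 1 to compound 4 (beyond the scatter) is large and beyond the scatter. From the compounds shown here alone, whether an amine or a carboxylic acid on this carbonyl carbon would stay within the scatter remains open, as does where a selenium-bearing group on the chain would fall. No evidence at hand explains any of these steps.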